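A few compounds are considered here, and "the series" means these few. Any claim that something is new, unique, unknown or untested is made for them only; others in the source may bear on it.

In a functional assay on MCF7 cells (Homo sapiens) for antiproliferative activity, read by MTT assay, with a stated time of 72 h (on this read-out higher numbers stand for weaker inhibition and lower numbers for stronger inhibition), compound 1 `CC1=CC[C@H]2[C@H](CC[C@]2(C)O)C(C)(C)[C@@H]1CC[C@H]1[C@]2(C)CC[C@H](OC(=O)c3ccc(C)cc3)C(C)(C)O[C@H]2CC[C@@]1(C)O` gives > 50000 nM as a limit of the assay and not a number. Going by the values given here, compound 2 `CC1=CC[C@H]2[C@H](CC[C@]2(C)O)C(C)(C)[C@@H]1CC[C@H]1[C@]2(C)CC[C@H](OC(=O)c3ccc(Cl)cc3)C(C)(C)O[C@H]2CC[C@@]1(C)O` gives 24100 nM and compound 3 `CC1=CC[C@H]2[C@H](CC[C@]2(C)O)C(C)(C)[C@@H]1CC[C@H]1[C@]2(C)CC[C@H](OC(=O)c3ccc([N+](=O)[O-])cc3)C(C)(C)O[C@H]2CC[C@@]1(C)O` gives 21600 nM as the only two true numbers so far, with a 1.1-fold lower number from compound 2 to compound 3 (0.05 log units; within the scatter) leaving compound 3 level with compound 2. Next comes compound 4 `CC1=CC[C@H]2[C@H](CC[C@]2(C)O)C(C)(C)[C@@H]1CC[C@H]1[C@]2(C)CC[C@H](OC(=O)c3cccc([N+](=O)[O-])c3)C(C)(C)O[C@H]2CC[C@@]1(C)O` which carries 3-nitrophenyl in place of 4-nitrophenyl on a carbonyl carbon. Among the compounds with values here, no measured step moves a group in this way. The nearest guides are the swaps on the aromatic carbon: an at least 2.0-fold lower number from compound 1 to compound 2 (0.31 log units; beyond the scatter) and an at least 2.3-fold lower number from compound 1 to compound 3 (0.36 log units; beyond the scatter) are at least modest and start from a limit, while the swap of nitro for chloro stays within the scatter. On that basis no step beyond the scatter is expected in this assay for this change. The expected change is a 1.2-fold higher number from compound 3 to compound 4 (0.08 log units; within the scatter) with no firm direction behind it. For compound 4 the expected value is 26000 nM with an estimated range from 13000 nM to 50000 nM as the working span.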

Compound 4, half-maximal inhibitory concentration: 36000 nM
Beside the measured number, compound 4's estimate is 1.4-fold (0.14 log units) below it; the measured number falls inside the stated range.
By their numbers in this assay, from the lowest: compounds 3, 2 and 4 (each within the scatter of the next). At a limit, above all of these: compound 1.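

Going by these compounds alone, the series now gives a first reading on where the nitro group sits: in this assay, 3-nitrophenyl in place of 4-nitrophenyl on a carbonyl carbon gives a 1.7-fold higher number from compound 3 to compound 4 (0.22 log units; within the scatter), so this move does not separate the two compounds. Likewise, a 1.5-fold higher number from compound 2 to compound 4 (0.17 log units; within the scatter) leaves 3-nitrophenyl level with 4-chlorophenyl. The comparison with 4-methylphenyl gives an at least 1.3-fold lower number from compound 1 to compound 4 (0.14 log units; that floor lies within the scatter), a floor that, unlike those for the 4-chlorophenyl and 4-nitrophenyl compounds, does not clear the scatter, and no more can be read because compound 1 stands at a limit of the assay: the limit of > 50000 nM in this assay, at which 1 of the 4 values shown sits.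

Still open, as far as these compounds go, is whether an amine or a carboxylic acid on the aromatic ring would give a step beyond the scatter from these compounds. The same question stands for a longer chain in place of the aromatic ring on the carbonyl carbon.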